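Cytotoxicity notes: aryl ketone replaces aryl ether

The source may report more compounds than this note shows. Statements on the series, on what has been measured and on what is new or still open speak of the compounds shown alone.

Of the compounds shown here, three of the shared core have been tested in an ADME assay on cells (Homo sapiens) for cytotoxicity, read by resazurin assay, with a stated time of 5 days; a lower number here means that less compound is tolerated, a higher number that more compound is tolerated. Compound 1 `COc1ccc(-c2nc(CSc3cccc(Br)c3)nc3ccsc23)cn1` gives only a limit of the assay, > 50000 nM. Compound 2 `COc1ccc(-c2nc(C(C)(C)S(=O)(=O)c3cccc(Cl)c3)nc3ccsc23)cn1` likewise gives a limit, > 50000 nM. Compound 3 `COc1ccc(-c2nc(COc3cccc(Cl)c3)nc3ccsc23)cn1` also gives a limit, > 50000 nM. On the numbers shown, compound 3 therefore stands where every value shown stands, at the limit of > 50000 nM in this assay, at which 3 of the 3 values shown sit. Among the compounds with values here, the single step between measured compounds, a step that the two limits leave unreadable from compound 1 to compound 3, runs from one limit to another and so has no readable size or direction.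

Compound 4 `COc1ccc(-c2nc(CC(=O)c3cccc(Cl)c3)nc3ccsc23)cn1` has not yet been measured. It differs from compound 3 in one place: (3-chlorophenyl)carbonyl in place of 3-chlorophenoxy on a saturated chain carbon bound to an aromatic carbon. Within the data shown here, the one measured step bears on it only in that two close variants of the same core sit at the same limit, so no size or direction can be taken from it. The step that the limit leaves unreadable from compound 3 to compound 4 is therefore expected to be none beyond the scatter. Compound 4 is expected to give about 60000 nM in this assay, within 20000 nM to 200000 nM, most likely again reported only as a limit.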

Compound 4, half-maximal cytotoxic concentration: 30000 nM
The estimate for compound 4 lay 2.0-fold (0.30 log units) above the measured number, within the range that was stated.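

In this assay, within the data shown here, compound 4 is the only one of the four compounds to give a number and not a limit, so a change at this place on a saturated chain carbon bound to an aromatic carbon can now be partly read. The other three compounds share a single reading: the limit of > 50000 nM in this assay, at which 3 of the 4 values shown sit. Placing (3-chlorophenyl)carbonyl in this position gives an at least 1.6-fold lower number from compound 3 to compound 4 (0.22 log units; that floor lies within the scatter), and the comparison with the sulfanyl compound gives an at least 1.6-fold lower number from compound 1 to compound 4 (0.22 log units; that floor lies within the scatter), so neither floor shows on its own that the carbonyl lowers the tolerated concentration.

Going by these compounds, the true values of compound 1 and compound 3 remain unknown, which leaves the full size of both steps open. Also open, on these data alone, is whether an amide or an amine in this position would give a number or a limit in this assay.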